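Aryl ester variation on a shared dihydropyranone core

This account rests on a few compounds, and the source may have more. Where it says the series, first, only, none or still open, it means among the compounds named here.

Measured compounds in a functional assay on MDA-MB-231 cells (Homo sapiens) for antiproliferative activity, read by MTT assay, with a stated time of 6 days; a higher number here means a weaker inhibitor, a lower number a stronger inhibitor:
- Compound 1, `CC(=O)O[C@@H]1C=CC(=O)O[C@@H]1[C@@H](COC(=O)c1ccc(Cl)cc1)OC(C)=O`: 1850 nM
- Compound 2, `CC(=O)O[C@@H]1C=CC(=O)O[C@@H]1[C@@H](COC(=O)c1ccc([N+](=O)[O-])cc1)OC(C)=O`: 4120 nM
- Compound 3, `O=C1C=C[C@@H](OCc2ccccc2)[C@@H]([C@@H](COC(=O)/C=C/c2ccccc2)OCc2ccccc2)O1`: 4970 nM

Compound 3 gives the highest of the three numbers. Its nearest neighbour is compound 2, within the scatter, so no order between the two can be stated; compound 1 sits further off, beyond the scatter, with the lower number.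

Compound 4, `COc1ccc(/C=C/C(=O)OC[C@@H](OCc2ccccc2)[C@H]2OC(=O)C=C[C@H]2OCc2ccccc2)cc1`, is the untested member. Relative to compound 3 the change is methoxy in place of hydrogen on an aromatic carbon. For the measured compounds named here, no measured step touches the cinnamate aryl ring or a methoxy group. Going by the values given here, the only step with a substituent change on an aromatic carbon is a 2.2-fold higher number from compound 1 to compound 2 (0.35 log units; beyond the scatter), which sits on a different ester and a different substituent pair, so it sets a rough scale for such changes rather than a direction.

For compound 4 the expected change is a 1.0-fold higher number from compound 3 to compound 4 (0.00 log units; within the scatter), i.e. nothing beyond the scatter is expected. The estimate for compound 4 is 5000 nM, range 2500 nM to 10000 nM.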

Compound 4, half-maximal inhibitory concentration: 3260 nM
The estimate for compound 4 lay 1.5-fold (0.19 log units) above the measured number; the range from low to high includes it.
By their numbers in this assay, from the lowest: compounds 1, 4, 2 and 3 (each within the scatter of the next, the first and the last beyond it).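

In this assay, methoxy in place of hydrogen on an aromatic carbon, para to a large group, gives a 1.5-fold lower number from compound 3 to compound 4 (0.18 log units; within the scatter), so compound 3 and compound 4 cannot be ordered and this single pair shows no effect of the change on the number. For the compounds shown here, the only other aromatic substituent step, a 2.2-fold higher number from compound 1 to compound 2 (0.35 log units; beyond the scatter), lies beyond the scatter, but it sits on a different ester and involves a different substituent pair, so it does not carry over to this position. No supporting data bear on why the methoxy change leaves the number within the scatter.

Still open, as far as these compounds go, is whether an amine, a carboxylic acid or a longer chain such as butoxy at this same ring carbon would give a step beyond the scatter. Also open, from the compounds shown here alone, is whether chloro or nitro on this ring would behave as they do on the benzoate esters.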